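The compounds below may be only part of what the source reports. "The series", "measured", "known", "first", "only" and "open" are said of these compounds alone.

In a functional assay on SW 1116 cells (Homo sapiens) for cytotoxicity, read by MTT assay, with a stated time of 48 h (on this read-out higher numbers stand for weaker inhibition and lower numbers for stronger inhibition), compound 3 `O=C(CSc1nnc(-c2ccncc2)o1)N/N=C/c1cccc(F)c1` gives 26700 nM, the highest of the three numbers on hand, though its gaps to compound 2 `O=C(CSc1nnc(-c2ccncc2)o1)N/N=C/c1ccc(Br)cc1` at 21300 nM and to compound 1 `O=C(CSc1nnc(-c2ccncc2)o1)N/N=C/c1ccc(F)cc1` at 15700 nM both lie within the scatter. Compound 4 `O=C(CSc1nnc(-c2ccncc2)o1)N/N=C/c1cc(Cl)ccc1O` differs from compound 3 by 5-chloro-2-hydroxyphenyl in place of 3-fluorophenyl on a carbon with a double bond to nitrogen. Going by the values given here, the measured steps that touch the same aryl group, a 1.7-fold higher number from compound 1 to compound 3 (0.23 log units; within the scatter) and a 1.3-fold higher number from compound 2 to compound 3 (0.10 log units; within the scatter), and the halogen exchange a 1.4-fold higher number from compound 1 to compound 2 (0.13 log units; within the scatter), all fell within the scatter, and none of them brings in a hydroxyl, so the entering group has no measured precedent here. On that basis no step beyond the scatter is expected for compound 4, namely a 1.1-fold lower number from compound 3 to compound 4 (0.03 log units; within the scatter). The value of compound 4 in this assay is therefore estimated at 25000 nM, within a range from 8000 nM to 80000 nM.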

Compound 4, half-maximal inhibitory concentration: 5240 nM
Compound 4: the middle estimate sits 4.8-fold (0.68 log units) above what was measured; measured number outside the range, below it.
By their numbers in this assay, from the lowest: compound 4; then compounds 1, 2 and 3 (each within the scatter of the next).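

In this assay, the aryl group on the carbon with a double bond to nitrogen proves able to move the read-out beyond the scatter, since 5-chloro-2-hydroxyphenyl gives a 5.1-fold lower number from compound 3 to compound 4 (0.71 log units; beyond the scatter), a 4.1-fold lower number from compound 2 to compound 4 (0.61 log units; beyond the scatter) and a 3.0-fold lower number from compound 1 to compound 4 (0.48 log units; beyond the scatter). The exchanges among compound 1, compound 2 and compound 3 had shown no such step. No measurement shown here speaks to why this change has that effect.

The hydroxyl and the chlorine enter together, so their shares in the step stay unseparated. As far as these compounds go, how an amine or a methoxy group would fare in place of that hydroxyl remains open.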